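Enantiomeric fluorocyclopropyl amide on a bicyclic diamine core

The source may hold more compounds than are shown below. What is called first, only, known or untested is meant among the compounds shown, and "the series" means these compounds.

Measured so far:
Compound 1 `CCCC(=O)N1CC2CC(C1)N2`: 580 nM
Compound 2 `O=C([C@H]1C[C@@H]1F)N1CC2CC(C1)N2`: 850 nM

In an assay on SH-EP1 cells for agonist activity at Neuronal acetylcholine receptor; alpha4/beta2 (Homo sapiens), read by FLIPR and calcium flux (a lower number here means that less compound is needed, a higher number that more compound is needed for the effect), compound 1 gives 580 nM and compound 2 gives 850 nM; the step of a 1.5-fold higher number from compound 1 to compound 2 (0.17 log units; within the scatter) places the two within the usual scatter of each other, so compound 2 stands beside compound 1 with no separation. Compound 3 `O=C([C@@H]1C[C@H]1F)N1CC2CC(C1)N2` differs from compound 2 only in configuration: the two compounds have the same atoms and bonds; at least one stereo element is drawn with a configuration in one of them and without one in the other: 2 of 4 stereo elements differ; a stereocentre at a saturated ring carbon is drawn R in compound 2 and S in compound 3; a stereocentre at a saturated ring carbon is drawn S in compound 2 and R in compound 3. No measured step involves a change of stereochemistry, so the listed steps do not bear on this one, and the direction cannot be inferred. Compound 3 is expected to give 1000 nM in this assay, within 300 nM to 4000 nM, a step of a 1.2-fold higher number from compound 2 to compound 3 (0.07 log units; within the scatter) that is estimated with wide uncertainty.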

Compound 3, half-maximal effective concentration: 120 nM
Compound 3: middle estimate off by 8.3-fold (0.92 log units), on the high side; measured number outside the range, below it.
By their numbers in this assay, from the lowest: compound 3; then compounds 1 and 2 (each within the scatter of the next).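

In this assay, the configuration of the 2-fluorocyclopropyl group on the carbonyl carbon proves to matter, giving a 7.1-fold lower number from compound 2 to compound 3 (0.85 log units; beyond the scatter) with atoms and bonds unchanged. Replacing propyl with this group can therefore shift the number beyond the scatter, as a 4.8-fold lower number from compound 1 to compound 3 (0.68 log units; beyond the scatter) shows, although compound 2 had stayed within the scatter of compound 1. The reading of this configuration carries one caution: the fact that one of compounds 2 and 3 is drawn with a defined configuration and the other without, at the place where they differ.

Going by these compounds, whether a plain cyclopropyl without fluorine would sit nearer compound 2 or compound 3 remains open. So does whether a 2-chlorocyclopropyl group would show the same dependence on configuration.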